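This account rests on a few compounds, and the source may have more. Where it says the series, first, only, none or still open, it means among the compounds named here.

Going by the values given here, in a functional assay on A2780 cells (Homo sapiens) for inhibition, with a stated time of 72 h (on this read-out lower numbers stand for stronger inhibition and higher numbers for weaker inhibition), compound 2 `CC1(C)CC(C)(C)c2cc(NC(=O)Nc3ccc(C#N)cc3)ccc2O1` gives 4700 nM; the only other measured compound, compound 1 `CC1(C)CC(C)(C)c2cc(NC(=O)Nc3ccc([N+](=O)[O-])cc3)ccc2O1`, gives 4100 nM, which lies within the scatter of that figure. Compound 3 `CC1(C)CC(C)(C)c2cc(NC(=O)Nc3ccc(C(F)(F)F)cc3)ccc2O1` differs from compound 2 by one change: trifluoromethyl in place of cyano on an aromatic carbon. Among the compounds with values here, the single measured step that bears on this, also an exchange of the group sitting in that place, was a 1.1-fold higher number from compound 1 to compound 2 (0.06 log units; within the scatter). No movement beyond the scatter is therefore expected, a 1.0-fold lower number from compound 2 to compound 3 (0.02 log units; within the scatter). Compound 3 is estimated at 4500 nM in this assay, with a range from 2000 nM to 10000 nM.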

Compound 3, half-maximal inhibitory concentration: 3600 nM
The estimate for compound 3 lay 1.3-fold (0.10 log units) above the measured number; the measured number falls inside the stated range.
By their numbers in this assay, from the lowest: compounds 3, 1 and 2 (each within the scatter of the next).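

In this assay, trifluoromethyl on this aromatic carbon, para to a large group, gives no step beyond the scatter from either earlier group, cyano (a 1.3-fold lower number from compound 2 to compound 3 (0.12 log units; within the scatter)) or nitro (a 1.1-fold lower number from compound 1 to compound 3 (0.06 log units; within the scatter)). This change adds a third group with more heavy atoms and no hydrogen-bond acceptor, yet all three compounds still lie within the scatter of one another. Nothing available accounts for this lack of separation. As far as these compounds go, whether an amine, a carboxylic acid or a longer chain in this place would move the number beyond the scatter remains open. So does the effect of changes elsewhere on the shared core.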